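The source may hold more compounds than are shown below. What is called first, only, known or untested is meant among the compounds shown, and "the series" means these compounds.

Measured so far in a functional assay on MCF7 cells (Homo sapiens) for cytotoxicity, read by MTT assay, with a stated time of 72 h; on this read-out lower numbers stand for stronger inhibition and higher numbers for weaker inhibition:
- compound 1 `O=C(N/N=C/c1cccc(Cl)c1Cl)Nc1cc2c(Nc3ccc(F)c(Cl)c3)ncnc2cc1O[C@H]1CCOC1` gives "not active" (no number reported) as its result
- compound 2 `O=C(N/N=C/c1cc(Br)c(O)c(Br)c1)Nc1cc2c(Nc3ccc(F)c(Cl)c3)ncnc2cc1O[C@H]1CCOC1` gives 5910 nM as its result
- compound 3 `CC(C)(C)c1cc(/C=N/NC(=O)Nc2cc3c(Nc4ccc(F)c(Cl)c4)ncnc3cc2O[C@H]2CCOC2)cc(C(C)(C)C)c1O` gives 14500 nM as its result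

Compound 1 has no single number on this read-out: compound 1 is recorded as "not active" (no number reported) and cannot be placed on a scale. One structural change leads onward: 4-hydroxyphenyl in place of 2,3-dichlorophenyl on a carbon with a double bond to nitrogen puts 4-hydroxyphenyl in place of 2,3-dichlorophenyl on a carbon with a double bond to nitrogen. The product, compound 4 `O=C(N/N=C/c1ccc(O)cc1)Nc1cc2c(Nc3ccc(F)c(Cl)c3)ncnc2cc1O[C@H]1CCOC1`, awaits measurement. Compound 2 at 5910 nM and compound 3 at 14500 nM also carry a hydroxyl on their phenyl ring and give numbers. A step toward stronger inhibition in this assay is therefore expected, though its size cannot be stated without a number for the starting point. For compound 4 the estimated value is 8000 nM, within an expected range of 2500 nM to 30000 nM overall.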

Compound 4, half-maximal inhibitory concentration: 910 nM
The estimate for compound 4 lay 8.8-fold (0.94 log units) above the measured number; measured number outside the range, below it.
By their numbers in this assay, from the lowest: compound 4; then compound 2; then compound 3.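

In this assay, 4-hydroxyphenyl in place of 3,5-dibromo-4-hydroxyphenyl on a carbon with a double bond to nitrogen gives a 6.5-fold lower number from compound 2 to compound 4 (0.81 log units; beyond the scatter) and shows that, with the hydroxyl kept, the number at this position still depends on the other groups on the ring. Compound 1 has no number, so its change to compound 4 cannot be read as a step. Nothing measured here explains the difference. The compounds shown leave open how a methoxy group or an amine in place of the hydroxyl would read, and whether a single bromine would give a number closer to that of compound 4.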